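The compounds below may be only part of what the source reports. "The series", "measured", "known", "first", "only" and "open" are said of these compounds alone.

Values in a functional assay on Raji cells (Homo sapiens) for antiproliferative activity, read by MTT assay, with a stated time of 72 h (on this read-out higher numbers stand for weaker inhibition and lower numbers for stronger inhibition), so far:
- compound 1 `O=C1C[C@@H]2O[C@@H](Cc3ccccc3)[C@@H](O)[C@@H]2O1` gives 30 nM as its value
- compound 2 `O=C1C[C@@H]2O[C@H]3[C@H](c4ccccc4)c4ccccc4CO[C@H]3[C@@H]2O1` gives 15900 nM as its value

Compound 2 holds the higher number of the two, beyond the scatter from compound 1. Compound 3 `O=C1C[C@H]2O[C@@H]3[C@@H](c4ccccc4)c4ccccc4CO[C@@H]3[C@H]2O1` is the mirror image of compound 2, with the two compounds have the same atoms and bonds and differ only in configuration as drawn: 5 of 5 stereo elements differ (all stereocentres are inverted: mirror images); a stereocentre at a saturated ring carbon is drawn S in compound 2 and R in compound 3; a stereocentre at a saturated ring carbon is drawn S in compound 2 and R in compound 3; a stereocentre at a saturated ring carbon is drawn R in compound 2 and S in compound 3; a stereocentre at a saturated ring carbon is drawn R in compound 2 and S in compound 3 as the whole change. In this assay, within the data shown here, no mirror-image pair has been measured yet, so the size of any step is uncertain. Compound 1 at 30 nM shows that far lower numbers occur in this series. A modest shift toward stronger inhibition is therefore expected, with the estimated 2.7-fold lower number from compound 2 to compound 3 (0.42 log units; beyond the scatter) lying just beyond the scatter. Compound 3 is estimated at 6000 nM within a range of 800 nM to 30000 nM in this measurement.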

Compound 3, half-maximal inhibitory concentration: 460 nM
Compound 3: middle estimate off by 13-fold (1.12 log units), on the high side; the whole stated range lies above it.
By their numbers in this assay, from the lowest: compound 1; then compound 3; then compound 2.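

In this assay the mirror-image pair gives the first measure of what configuration alone does in this series, a large step with a 35-fold lower number from compound 2 to compound 3 (1.54 log units; beyond the scatter). No atom or bond changes, so the whole step belongs to the handedness of the shared core: the fact that compounds 2 and 3 differ only in the configuration as drawn. Activity in these cells therefore depends on absolute configuration, which compounds 1 and 2 alone could not show.

As far as these compounds go, all stereocentres invert together here, so which of them carries the step stays open. From the compounds shown here alone, whether an amine or a carboxylic acid on the shared core would keep the activity of compound 3 also stays open.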